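Benzofuran sulfonamide series: aryl change on the sulfonyl group

The compounds below may be only part of what the source reports. "The series", "measured", "known", "first", "only" and "open" are said of these compounds alone.

Measured so far:
compound 1 `CCOC(=O)c1oc2ccc(NS(=O)(=O)c3cccc(Cl)c3)cc2c1C` gives 57300 nM
compound 2 `CCOC(=O)c1oc2ccc(NS(=O)(=O)c3cccc(C(F)(F)F)c3)cc2c1C` gives 30200 nM

In a functional assay on MDA-MB-231 cells (Homo sapiens) for antiproliferative activity, read by MTT assay, with a stated time of 72 h (a higher number here means a weaker inhibitor, a lower number a stronger inhibitor), compound 1 and compound 2 sit within the scatter of each other: a 1.9-fold lower number from compound 1 to compound 2 (0.28 log units; within the scatter). No other measured value exists, so compound 1 has no step beyond the scatter to set it apart from the rest of the series.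

Compound 3 `CCOC(=O)c1oc2ccc(NS(=O)(=O)c3ccccc3[N+](=O)[O-])cc2c1C` is the next member. It differs from compound 1 in that (2-nitrophenyl in place of 3-chlorophenyl on a sulfonyl sulfur). For the measured compounds named here, only one measured step bears on changes at the sulfonyl aryl, the move from compound 1 to compound 2, and that step stayed within the scatter. Nothing measured speaks to a 2-nitrophenyl group at this place, so no direction in this assay can be argued from the data; the default expectation is a step no larger than the scatter.

Compound 3 is therefore estimated at 50000 nM (range 15000 nM to 160000 nM), which amounts to an expected step of a 1.1-fold lower number from compound 1 to compound 3 (0.06 log units; within the scatter).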

Compound 3, half-maximal inhibitory concentration: 80400 nM
Compound 3: the middle estimate sits 1.6-fold (0.21 log units) below what was measured; measured number inside the range.
By their numbers in this assay, from the lowest: compounds 2, 1 and 3 (each within the scatter of the next, the first and the last beyond it).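

In this assay, 2-nitrophenyl in place of 3-chlorophenyl on a sulfonyl sulfur gives a 1.4-fold higher number from compound 1 to compound 3 (0.15 log units; within the scatter) and so stays within the scatter. This second step at the position extends the earlier finding to a group that carries hydrogen-bond acceptors, which 3-chlorophenyl lacks, and to a different substitution pattern on the aryl ring, yet it sets compound 3 no further from compound 1 than the scatter allows. No supporting data bear on why this exchange leaves the number within the scatter.

The compounds shown leave open whether a simple unsubstituted phenyl, or an aryl ring bearing an amine or a carboxylic acid, would give a step beyond the scatter at this place. They also leave open what replacing the ethyl ester on the shared core with a carboxylic acid or an amide would do.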